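Moving Two Fluorines Around a Benzyl Ring

This account rests on a few compounds, and the source may have more. Where it says the series, first, only, none or still open, it means among the compounds named here.

Among the measured compounds shown here, in an assay on FRT cells for positive allosteric modulation of Cystic fibrosis transmembrane conductance regulator variant N1303K (Homo sapiens), in the presence of a further agent that is not named here (on this read-out lower numbers stand for an effect already at smaller amounts and higher numbers for an effect only at larger amounts of compound), compound 2 `COc1ccc2[nH]c3c(c2c1)CCNC31CCN(Cc2cc(F)ccc2F)CC1` gives 11100 nM, one of only two numbers measured so far and within the scatter of the other. That other compound, compound 1 `COc1ccc2[nH]c3c(c2c1)CCNC31CCN(Cc2ccc([N+](=O)[O-])cc2F)CC1`, gives 5900 nM in this assay; the step of a 1.9-fold higher number from compound 1 to compound 2 (0.27 log units; within the scatter) is within the scatter. Compound 3 `COc1ccc2[nH]c3c(c2c1)CCNC31CCN(Cc2ccc(F)c(F)c2)CC1` differs from compound 2 by 3,4-difluorophenyl in place of 2,5-difluorophenyl on a saturated chain carbon bound to an amine nitrogen in a ring. For the measured compounds named here, no measured step moves fluorines around the ring, and the one step available stayed within the scatter, so no change beyond the scatter is expected, a 1.1-fold lower number from compound 2 to compound 3 (0.05 log units; within the scatter). Compound 3 is therefore estimated at 10000 nM, with a range from 3500 nM to 30000 nM.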

Compound 3, half-maximal effective concentration: 11000 nM
Compound 3: the middle estimate sits 1.1-fold (0.04 log units) below what was measured; the measured number falls inside the stated range.
By their numbers in this assay, from the lowest: compounds 1, 3 and 2 (each within the scatter of the next).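

Placing the two fluorines as 3,4-difluorophenyl rather than 2,5-difluorophenyl gives compounds that cannot be told apart in this assay (a 1.0-fold lower number from compound 2 to compound 3 (0.00 log units; within the scatter)). Compound 3 also stays level with the nitro-bearing compound 1 (a 1.9-fold higher number from compound 1 to compound 3 (0.27 log units; within the scatter)), so all three benzyl groups shown lie within the scatter of one another. Nothing at hand gives a reason for this result.

Still open, as far as these compounds go, is whether an amine or a carboxylic acid on this ring would give a number beyond the scatter. Also open, from the compounds shown here alone, is what a plain phenyl ring without fluorine would give.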